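The source may hold more compounds than are shown below. What is called first, only, known or untested is meant among the compounds shown, and "the series" means these compounds.

Compound 1 `O=C(O)Cc1sc(C(c2ccc(F)cc2)c2ccc(F)cc2)nc1-c1cc(F)cc(F)c1`: 340 nM
Compound 2 `N#Cc1ccc(-c2nc(C(c3ccc(F)cc3)c3ccc(F)cc3)sc2CC(=O)O)cc1`: 1500 nM
Compound 3 `N#Cc1cc(-c2nc(C(c3ccc(F)cc3)c3ccc(F)cc3)sc2CC(=O)O)ccc1F`: 520 nM

In an in vitro functional assay on HEK285-7 cells for antagonist activity at prostaglandin D2 receptor 2 (Homo sapiens), read by BRET and beta-arrestin recruitment (on this read-out higher numbers stand for weaker inhibition and lower numbers for stronger inhibition), compound 3 gives 520 nM, the second highest of the three numbers. Its distance from compound 1 is small, since a 1.5-fold higher number from compound 1 to compound 3 (0.18 log units; within the scatter) lies within the scatter, whereas a 2.9-fold lower number from compound 2 to compound 3 (0.46 log units; beyond the scatter) lies beyond it. Compound 4 `NS(=O)(=O)c1ccc(-c2nc(C(c3ccc(F)cc3)c3ccc(F)cc3)sc2CC(=O)O)cc1` carries 4-sulfamoylphenyl in place of 3-cyano-4-fluorophenyl on an aromatic carbon. Among the measured compounds shown here, two measured steps bear on this change: a 4.4-fold higher number from compound 1 to compound 2 (0.64 log units; beyond the scatter), where a 4-cyanophenyl replaced the 3,5-difluorophenyl, and a 2.9-fold lower number from compound 2 to compound 3 (0.46 log units; beyond the scatter). Since the only other 4-substituted phenyl in this set, compound 2, gave 1500 nM, a weakening step of a 2.9-fold higher number from compound 3 to compound 4 (0.46 log units; beyond the scatter) is expected for compound 4. Compound 4 is therefore estimated at 1500 nM, within a range of 500 nM to 4500 nM.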

Compound 4, half-maximal inhibitory concentration: > 100000 nM
Compound 4 gave a limit, no number (the forecaster's own chance of this, stated with the estimate: 5%); middle value at least 66-fold (1.82 log units) from the limit.
By their numbers in this assay, from the lowest: compounds 1 and 3 (each within the scatter of the next); then compound 2. At a limit, above all of these: compound 4.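

In this assay compound 4 gives only a limit, not a number: the limit of > 100000 nM in this assay, at which 1 of the 4 values shown sits. Sulfamoyl in place of cyano on this aromatic carbon gives an at least 66-fold higher number from compound 2 to compound 4 (1.82 log units; beyond the scatter), a far larger step than any among the earlier compounds, whose changes at this position stayed modest or within the scatter. The other two steps are of the same large size, an at least 190-fold higher number from compound 3 to compound 4 (2.28 log units; beyond the scatter) and an at least 290-fold higher number from compound 1 to compound 4 (2.46 log units; beyond the scatter), so the group at this position can separate a measurable value from a limit.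

The compounds shown leave open whether a methylsulfonyl or a carboxamide group in place of sulfamoyl would behave like cyano or like sulfamoyl.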